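The source may report more compounds than this note shows. Statements on the series, on what has been measured and on what is new or still open speak of the compounds shown alone.

- compound 1 `Cc1ccc(/C=N/NC(=O)CSc2nnc(-c3ccncc3)o2)cc1` gives 21800 nM
- compound 2 `O=C(CSc1nnc(-c2ccncc2)o1)N/N=C/c1cc(Br)ccc1O` gives 9590 nM

Both values come from a functional assay on BGC-823 cells (Homo sapiens) for cytotoxicity, read by MTT assay, with a stated time of 48 h (on this read-out higher numbers stand for weaker inhibition and lower numbers for stronger inhibition), and compound 2 holds the lower of the two numbers. Compound 3 `O=C(CSc1nnc(-c2ccncc2)o1)N/N=C/C=C/c1ccccc1` has not yet been measured. It carries 2-phenylethenyl in place of 5-bromo-2-hydroxyphenyl on a carbon with a double bond to nitrogen. Within the data shown here, only one measured step bears on this change: a 2.3-fold lower number from compound 1 to compound 2 (0.36 log units; beyond the scatter), which is modest and beyond the scatter. Among the measured compounds shown here, that step ends on the same 5-bromo-2-hydroxyphenyl group that is now replaced, although no compound with 2-phenylethenyl has a measured value. A modest move to a higher number in this assay, similar in size to that step, is therefore expected. The estimated change is a 2.2-fold higher number from compound 2 to compound 3 (0.34 log units; beyond the scatter), with considerable uncertainty. Compound 3 is expected at 21000 nM, with an estimated range from 8000 nM to 50000 nM overall.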

Compound 3, half-maximal inhibitory concentration: 10600 nM
Compound 3: middle estimate off by 2.0-fold (0.30 log units), on the high side; the measured number falls inside the stated range.
By their numbers in this assay, from the lowest: compounds 2 and 3 (each within the scatter of the next); then compound 1.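

In this assay, the place on a carbon with a double bond to nitrogen accepts 2-phenylethenyl with no readable loss against 5-bromo-2-hydroxyphenyl, with a 1.1-fold higher number from compound 2 to compound 3 (0.04 log units; within the scatter). The bromine, the oxygen and the hydrogen-bond donor and acceptor counted in the leaving group are therefore not required to reach this level, at least in this pair, and the separation from 4-methylphenyl is not unique to the bromo-hydroxy group, as a 2.1-fold lower number from compound 1 to compound 3 (0.31 log units; beyond the scatter) shows. Nothing measured here explains why these two different groups give matching numbers.

The compounds shown leave open whether the double bond outside the ring matters, which a saturated 2-phenylethyl group would test. They also leave open how an amine or a carboxylic acid on the phenyl ring would read at this place.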